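A few compounds are considered here, and "the series" means these few. Any claim that something is new, unique, unknown or untested is made for them only; others in the source may bear on it.

Measured so far in a functional assay on the whole organism with Rattus norvegicus as the target, at a dose of 3 mg/kg by the oral route; a higher number here means a stronger effect of the compound at the dose given, a lower number a weaker effect:

compound 1 `COc1cc(C(=O)Nc2nn[nH]n2)nc(-c2ccccc2)c1` gives 97%
compound 2 `COc1cc(C(=O)Nc2nn[nH]n2)nc(-c2cccc(Cl)c2)c1` gives 34%

Compound 2 stands lowest of the two numbers in this assay; its nearest neighbour is compound 1, which lies higher by a number 63 percentage points lower from compound 1 to compound 2 (beyond the scatter) read in reverse, a gap beyond the scatter.

Compound 3 `COc1cc(C(=O)Nc2nn[nH]n2)nc(-c2ccccc2OC)c1` is not yet measured. It differs from compound 2 by 2-methoxyphenyl in place of 3-chlorophenyl on an aromatic carbon.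

Within the data shown here, the only measured step that bears on this is a number 63 percentage points lower from compound 1 to compound 2 (beyond the scatter), where chloro in place of hydrogen on an aromatic carbon cost most of the effect. Among the measured compounds shown here, in compound 3 that chlorine is gone, which on this one step points back toward the level of compound 1, but a methoxy group enters at a different place on the same ring, and no measured step shows what such a group does here. The step is therefore expected to be a number 26 percentage points higher from compound 2 to compound 3 (beyond the scatter), a rise carrying wide uncertainty.

For compound 3 in this assay the estimate is 60%, with a range from 20% to 95%.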

Compound 3, a percentage reported as inhibition, in the whole organism at one dose (the size of the read-out at that dose, not a potency): 68%
The estimate for compound 3 lay 8 percentage points below the measured number; the range from low to high includes it.
By their numbers in this assay, from the lowest: compound 2; then compound 3; then compound 1.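

In this assay, the loss on substituting the phenyl ring is no longer tied to chlorine alone: a number 29 percentage points lower from compound 1 to compound 3 (beyond the scatter), so both substituted compounds shown lie under the unsubstituted phenyl of compound 1, with no exception so far. The substituted rings are nevertheless far from equivalent, since 2-methoxyphenyl in place of 3-chlorophenyl gives a number 34 percentage points higher from compound 2 to compound 3 (beyond the scatter), and the ring substituent therefore sets the size of the whole-animal effect at this dose, not merely its presence. No measurement on these compounds gives a reason for either step.

Compounds 2 and 3 differ in both the group and where it sits on the phenyl ring, so the compounds shown cannot tell whether the gap between them follows the change from chloro to methoxy or the change of ring position. Also open, from the compounds shown here alone, is how a fluoro, a methyl or an amine on this ring would compare with the plain phenyl of compound 1, and whether any group here keeps the effect at that level.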